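Methyl in Place of Phenyl on the Shared Core

The source may hold more compounds than are shown below. What is called first, only, known or untested is meant among the compounds shown, and "the series" means these compounds.

Compound 1 `O=C(CSc1nnc(-c2ccc(Cl)cc2)n1-c1ccccc1)NNC(=O)c1ccccc1O` — > 20000 nM
Compound 2 `Cc1cc(C)nc(SCc2nnc(SCC(=O)NNC(=O)c3ccccc3O)n2-c2ccccc2)n1` — > 20000 nM

In an ADME assay on MDA-MB-435 cells (Homo sapiens) for cytotoxicity (on this read-out lower numbers stand for higher toxicity in this test and higher numbers for lower toxicity in this test), compound 2 gives > 20000 nM, which is a limit of the assay and not a number. Compound 1 likewise gives > 20000 nM, also a limit. The step that the two limits leave unreadable from compound 1 to compound 2 therefore has no readable size; both values sit at the limit of > 20000 nM in this assay, at which 2 of the 2 values shown sit. Compound 3 `Cc1cc(C)nc(SCc2nnc(SCC(=O)NNC(=O)c3ccccc3O)n2C)n1` differs from compound 2 by methyl in place of phenyl on an aromatic nitrogen. No measured step reaches this position, so nothing shown points to a change in this assay beyond the scatter. Compound 3 is expected to stay at the limit, with an estimate of 20000 nM (range 10000 nM to 40000 nM), a step of a number no higher from compound 2 to compound 3 (the limit leaves the size open).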

Compound 3, half-maximal cytotoxic concentration: > 20000 nM
Compound 3 was reported as a limit; the forecaster's own chance of this, stated with the estimate: 85%; the middle value sits exactly at the limit.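

No size can be read for the step between compound 2 and compound 3, and compounds 1, 2 and 3 all share one assay limit: the limit of > 20000 nM in this assay, at which 3 of the 3 values shown sit.

The compounds shown leave open whether any change on the shared core gives a readable number in this assay.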